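Swapping pyridin-3-yl for 1H-pyrazol-3-yl: tolerance on Vero cells

The source may hold more compounds than are shown below. What is called first, only, known or untested is meant among the compounds shown, and "the series" means these compounds.

Compound 1 `Fc1ccc(-c2nn3c(NC4CCCC4)cccc3c2-c2ccnc(F)c2)cc1`: "not determined" (no result reported)
Compound 2 `Fc1ccc(-c2nn3c(NC4CCCC4)cccc3c2-c2cccnc2)cc1`: > 40000 nM

In an ADME assay on Vero cells (Chlorocebus sabaeus) for cytotoxicity (a higher number here means that more compound is tolerated, a lower number that less compound is tolerated), compound 1 has no reported result. Compound 2 reaches only the limit of the assay, > 40000 nM, so no single number is known for it; it stands at the limit of > 40000 nM in this assay, at which 1 of the 2 values shown sits. Among the compounds with values here, no step between measured compounds is available. Compound 3 `Fc1ccc(-c2nn3c(NC4CCCC4)cccc3c2-c2cc[nH]n2)cc1` carries 1H-pyrazol-3-yl in place of pyridin-3-yl on an aromatic carbon. The step that the limit leaves unreadable from compound 2 to compound 3 is expected to stay within the scatter, since compound 2 sits at the limit of > 40000 nM in this assay, at which 1 of the 2 values shown sits. Compound 3 is estimated at 45000 nM, in a range of 20000 nM to 100000 nM, most likely again reported as a limit.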

Compound 3, half-maximal cytotoxic concentration: 14000 nM
The estimate for compound 3 lay 3.2-fold (0.51 log units) above the measured number; the whole stated range lies above it.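

In this assay, the aromatic carbon carrying these rings proves sensitive to the group placed on it: 1H-pyrazol-3-yl in place of pyridin-3-yl gives an at least 2.8-fold lower number from compound 2 to compound 3 (0.45 log units; beyond the scatter). Compound 3 also supplies the only single number shown for this position. The size of the step has only a bound because compound 2 is held at a limit: the limit of > 40000 nM in this assay, at which 1 of the 3 values shown sits.

Whether the hydrogen-bond donor or the five-membered ring accounts for the change stays open. So does how a 1-methyl-1H-pyrazol-3-yl group or a plain phenyl ring on the same carbon would compare.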